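This account rests on a few compounds, and the source may have more. Where it says the series, first, only, none or still open, it means among the compounds named here.

Measured compounds:
compound 1 `Fc1ccc(CSc2nnc(-c3ccc4c(c3)OCCO4)o2)cc1` — 41200 nM
compound 2 `Clc1ccccc1CSc1nnc(-c2ccc3c(c2)OCCO3)o1` — 36800 nM
compound 3 `Cc1ccc(CSc2nnc(-c3ccc4c(c3)OCCO4)o2)cc1` — 45400 nM

All three were read in a functional assay on HeLa cells (Homo sapiens) for antiproliferative activity, read by MTT assay, with a stated time of 48 h; on this read-out higher numbers stand for weaker inhibition and lower numbers for stronger inhibition. Compound 3 stands highest of the three numbers, yet the steps of a 1.1-fold higher number from compound 1 to compound 3 (0.04 log units; within the scatter) and a 1.2-fold higher number from compound 2 to compound 3 (0.09 log units; within the scatter) both lie within the scatter, so no order among the three can be drawn. Compound 4 `Brc1ccccc1CSc1nnc(-c2ccc3c(c2)OCCO3)o1` differs from compound 3 by 2-bromophenyl in place of 4-methylphenyl on a saturated chain carbon bound to a sulfur. The steps bearing on this change are the aryl swaps a 1.1-fold lower number from compound 1 to compound 2 (0.05 log units; within the scatter) and a 1.2-fold higher number from compound 2 to compound 3 (0.09 log units; within the scatter), both within the scatter; compound 2, carrying 2-chlorophenyl at the same place, is the closest measured analogue. No step beyond the scatter is therefore expected in this assay, the expected step being a 1.2-fold lower number from compound 3 to compound 4 (0.08 log units; within the scatter). Compound 4 is estimated at 38000 nM, in a range from 19000 nM to 76000 nM.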

Compound 4, half-maximal inhibitory concentration: 22400 nM
For compound 4 the middle estimate is 1.7-fold (0.23 log units) above the measured one, and the stated range covers the measured number.
By their numbers in this assay, from the lowest: compounds 4, 2, 1 and 3 (each within the scatter of the next, the first and the last beyond it).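

In this assay the aryl group on a saturated chain carbon bound to a sulfur gives its first step beyond the scatter, a modest one: a 2.0-fold lower number from compound 3 to compound 4 (0.31 log units; beyond the scatter) with 2-bromophenyl in place of 4-methylphenyl. The steps of a 1.6-fold lower number from compound 2 to compound 4 (0.22 log units; within the scatter) and a 1.8-fold lower number from compound 1 to compound 4 (0.26 log units; within the scatter) both stay within the scatter, so compound 4 separates only from compound 3, and bromo and chloro cannot be told apart here. No measurement at hand bears on a cause for this step.

On these data alone, how an amine or a carboxylic acid on the aromatic ring, or a longer chain in place of the saturated chain carbon, would read remains open.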